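This account rests on a few compounds, and the source may have more. Where it says the series, first, only, none or still open, it means among the compounds named here.

Of the compounds shown here, three built on a shared core have been measured in a functional assay on A549 cells (Homo sapiens) for antiproliferative activity, read by MTT assay, with a stated time of 48 h; on this read-out higher numbers stand for weaker inhibition and lower numbers for stronger inhibition. Compound 1 `COc1cccc(-c2nn(-c3ccccc3)cc2C(Nc2nc3ccccc3s2)c2c(O)ccc3ccccc23)c1` gives 24800 nM in this assay. Compound 2 `COc1cccc(-c2nn(-c3ccccc3)cc2C(Nc2nc3ccc(Cl)cc3s2)c2c(O)ccc3ccccc23)c1` gives 49800 nM in this assay. Compound 3 `Oc1ccc2ccccc2c1C(Nc1nc2ccc(Cl)cc2s1)c1cn(-c2ccccc2)nc1-c1cccc(Cl)c1` gives 33300 nM in this assay. Compound 2 and compound 1 differ by hydrogen in place of chloro on an aromatic carbon, and that change gives a 2.0-fold lower number from compound 2 to compound 1 (0.30 log units; within the scatter). Compound 2 and compound 3 differ in their cores by chloro in place of methoxy on an aromatic carbon, a step of a 1.5-fold lower number from compound 2 to compound 3 (0.17 log units; within the scatter). All three numbers lie close together, so none of the three can be called more or less potent than another.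

Compound 4 `Oc1ccc2ccccc2c1C(Nc1nc2ccc(Cl)cc2s1)c1cn(-c2ccccc2)nc1-c1ccccc1` has not yet been measured. It differs from compound 3 by hydrogen in place of chloro on an aromatic carbon. Among the measured compounds shown here, this is the same kind of change as the one from compound 2 to compound 1, but not the same: there the hydrogen entered on a ring that is part of a fused or bridged system of two rings, meta to a fused ring and para to a fused ring, whereas here it enters on a six-membered aromatic ring of carbon only, meta to a large group. Because the earlier step of a 2.0-fold lower number from compound 2 to compound 1 (0.30 log units; within the scatter) stayed within the scatter, compound 4 is expected to give a number close to that of compound 3, with an expected step of a 1.5-fold lower number from compound 3 to compound 4 (0.18 log units; within the scatter). Compound 4 is thus estimated at 22000 nM in this assay, between 9000 nM and 55000 nM.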

Compound 4, half-maximal inhibitory concentration: 51100 nM
Compound 4: the middle estimate sits 2.3-fold (0.37 log units) below what was measured, and the stated range covers the measured number.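

In this assay, hydrogen in place of chloro on the 3-chlorophenyl group gives a 1.5-fold higher number from compound 3 to compound 4 (0.19 log units; within the scatter), and hydrogen in place of methoxy at that aromatic carbon gives a 1.0-fold higher number from compound 2 to compound 4 (0.01 log units; within the scatter), so both new steps are small when read alone. Set beside the earlier step at a different place in the molecule, the change from chloro to hydrogen does not carry from one core to the other as a fixed step, since the two steps run in opposite directions and the gap between them is larger than the scatter allows: the same change on two cores in this assay, a 2.0-fold lower number (0.30 log units; within the scatter) from compound 2 to compound 1 and a 1.5-fold higher number (0.19 log units; within the scatter) from compound 3 to compound 4, 3.1-fold (0.49 log units) apart, beyond the scatter of two such steps This does not show that either place responds reliably to the change, since each step alone stays within the scatter, and one pair on each core gives no rule for other cores in the series.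

The compounds shown leave open whether an amine, a carboxylic acid or a fluoro group on that six-membered aromatic ring, meta to a large group, would give a step beyond the scatter. They also leave open whether the gap between the two chloro-to-hydrogen steps would hold up in repeated measurements or on further matched pairs.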